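The source may report more compounds than this note shows. Statements on the series, on what has been measured and on what is new or still open speak of the compounds shown alone.

Working notes on the series. Compound 1 `CCC1(C)CC(=O)N(CC(=O)N2CCN(c3ccccc3Cl)CC2)C1=O` and compound 2 `CCC1(C)CC(=O)N(CC(=O)N2CCN(c3cccc(C(F)(F)F)c3)CC2)C1=O` share one core and differ only in a distal group. In a functional assay on the whole organism (strain CD1) with Mus musculus as the target, in the maximal electroshock model, with a stated time of 0.5 h (a lower number here means that less compound is needed, a higher number that more compound is needed for the effect), compound 1 gives 100 mg/kg. In the same assay compound 2 gives 100 mg/kg. Compound 1 thus stands level with compound 2 at the digits shown; the two values sit within the usual scatter, so neither is taken as needing more or less compound than the other.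

Compound 3 `CC1CC(=O)N(CC(=O)N2CCN(c3ccccc3Cl)CC2)C1=O` is to be measured in this assay. It differs from compound 1 in one place: hydrogen in place of ethyl on a saturated ring carbon. Among the compounds with values here, no measured pair tracks this change, so no step can be read from the data themselves, and the expectation rests only on the value of compound 1 and the nature of the change. The step is expected to be a 1.3-fold higher number from compound 1 to compound 3 (0.11 log units; within the scatter), in the direction of more compound needed, though small enough that it could still fall inside the scatter. For compound 3 the minimum effective dose is estimated at 130 mg/kg, with a range from 50 mg/kg to 300 mg/kg.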

Compound 3, minimum effective dose: 300 mg/kg
Compound 3: middle estimate off by 2.3-fold (0.36 log units), on the low side; low and high end bracket the measured number.
By their numbers in this assay, from the lowest: compounds 1 and 2 (each within the scatter of the next); then compound 3.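

Compounds 1 and 2 differ only in a distal group and stand level, so they say nothing about the saturated ring carbon two ring bonds from the ring nitrogen. Here, in this assay, hydrogen in place of ethyl gives a 3.0-fold higher number from compound 1 to compound 3 (0.48 log units; beyond the scatter), a modest step beyond the scatter, in the direction of more compound needed, so this position is not indifferent to the change in this read-out and the ethyl is linked to the lower dose within this pair. The change removes two carbons and adds or removes no hydrogen-bond donor, hydrogen-bond acceptor or net charge, yet no measurement shown here gives a reason for the step.

This single pair cannot show whether a propyl group, a longer chain or a phenyl group at the same ring carbon would lower the number or raise it further. It also leaves open whether the same step would appear with the trifluoromethyl-bearing distal group of compound 2, as the change is shown only with the distal group of compound 1.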